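The source may hold more compounds than are shown below. What is called first, only, known or untested is meant among the compounds shown, and "the series" means these compounds.

Measured so far:
- compound 1, `COC(=O)c1sc2cc(OC)ccc2c1Nc1cc(OC)c(OC)c(OC)c1`, 1.7 nM
- compound 2, `CCOC(=O)c1sc2c(OC)c(C)c(C)c(C)c2c1Nc1cc(OC)c(OC)c(OC)c1`, 56.5 nM

Notes on the series. Going by the values given here, in a functional assay on Jurkat cells (Homo sapiens) for cytotoxicity, read by MTT assay, with a stated time of 72 h (on this read-out lower numbers stand for stronger inhibition and higher numbers for weaker inhibition), compound 1 gives 1.7 nM, the lowest number of the two measured; the only other measured compound, compound 2, gives 56.5 nM, a higher number beyond the scatter. Among the compounds with values here, compound 2 differs from compound 1 in several places at once, so no single structural step between measured compounds is available and nothing can be said about which of those differences carries the gap.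

Compound 3, `COC(=O)c1sc2cc(C)ccc2c1Nc1cc(OC)c(OC)c(OC)c1`, has not yet been measured. It differs from compound 1 in one place: methyl in place of methoxy on an aromatic carbon. The group concerned sits on an aromatic carbon of a six-membered aromatic ring of carbon only, part of a fused or bridged system of two rings, meta to a fused ring and para to a fused ring.

With no measured step of this kind in hand, the expectation for this assay is a small shift towards a higher number, of a size near the scatter, rather than a large move. Compound 3 is therefore expected to give about 4 nM, within 1 nM to 15 nM, which means an expected step of a 2.4-fold higher number from compound 1 to compound 3 (0.37 log units; beyond the scatter).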

Compound 3, half-maximal inhibitory concentration: 0.6 nM
For compound 3 the middle estimate is 6.7-fold (0.82 log units) above the measured one, outside the stated range (below it).
By their numbers in this assay, from the lowest: compound 3; then compound 1; then compound 2.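

In this assay the series now has its first step at a single place, and it runs a 2.8-fold lower number from compound 1 to compound 3 (0.45 log units; beyond the scatter) when methyl takes the place of methoxy on this aromatic carbon. The methoxy group, with its oxygen and its hydrogen-bond acceptor, is therefore not required at this position for a low number in this pair: the smaller methyl group gives a modest move in the direction of stronger inhibition, beyond the scatter, where compounds 1 and 2 alone could say nothing about this position. Nothing available bears on the reason for this step, which stands as an observation only.

The compounds shown leave open whether the position accepts other groups, such as an amine, a chlorine atom, a hydroxyl group or a longer chain like ethyl or propyl, and whether the numbers follow any order across such groups. They also leave open whether the same change would carry over to the more heavily substituted core of compound 2, whose gap to the others still cannot be assigned to any single one of its differences.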